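Ester of the Hydroxyethyl Chain and Hepatoma Cell Cytotoxicity

The source may report more compounds than this note shows. Statements on the series, on what has been measured and on what is new or still open speak of the compounds shown alone.

Compound 1 `O=c1[nH]c2ccc(Cl)cc2c(-c2ccccc2Cl)c1CCO` carries a free 2-hydroxyethyl chain on the shared core. In an ADME assay on HepG2 2.2.15 cells (Homo sapiens) for cytotoxicity (on this read-out higher numbers stand for lower toxicity in this test and lower numbers for higher toxicity in this test), compound 1 gives 380000 nM. Among the measured compounds shown here, it is the only plain number among the values shown; the other value is a limit of the test. Compound 2 `O=c1c(CCO)c(-c2ccccc2Cl)c2cc(Cl)ccc2n1-c1c(F)cccc1F` reaches a limit of > 2300000 nM in this assay. For the measured compounds named here, the one measured step, an at least 6.0-fold higher number from compound 1 to compound 2 (0.78 log units; beyond the scatter), concerns the aromatic nitrogen and rests on (the limit of > 2300000 nM in this assay, at which 1 of the 2 values shown sits). Compound 3 `CCCC(=O)OCCc1c(-c2ccccc2Cl)c2cc(Cl)ccc2[nH]c1=O` differs from compound 1 elsewhere: propylcarbonyl in place of hydrogen on an oxygen on a saturated carbon. Going by the values given here, no measured step touches this oxygen on a saturated carbon, so the change from compound 1 to compound 2 offers no guide to the size or direction of this one. The expectation for compound 3 in this assay is therefore a step from compound 1 that stays within the usual scatter, no change at the digits printed from compound 1 to compound 3 (within the scatter). Compound 3 is thus estimated at 380000 nM in this assay, within a range from 150000 nM to 1000000 nM.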

Compound 3, half-maximal cytotoxic concentration: 52000 nM
Beside the measured number, compound 3's estimate is 7.3-fold (0.86 log units) above it; the whole stated range lies above it.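

The oxygen on a saturated carbon turns out to be a place where this read-out responds to change. Propylcarbonyl in place of hydrogen there gives a 7.3-fold lower number from compound 1 to compound 3 (0.86 log units; beyond the scatter) in this assay, a move toward higher toxicity in this test, so the free 2-hydroxyethyl chain of compound 1 is not a neutral site. Among the compounds shown here, the only earlier step, an at least 6.0-fold higher number from compound 1 to compound 2 (0.78 log units; beyond the scatter) at the aromatic nitrogen, runs the opposite way and rests on a limit of the test, so the two changes made to compound 1 now show that the number can move in either direction depending on the place altered. Nothing among the measurements shown bears on why the ester carries the lower number.

Going by these compounds, it remains open whether this step depends on the length of the acyl group, as an acetyl ester or a longer chain ester would show, or whether an amine or a carboxylic acid at the end of the chain would move the number in the same way. On these data alone, it is equally open whether the 2-((propylcarbonyl)oxy)ethyl chain would have the same effect on a core carrying 2,6-difluorophenyl on the aromatic nitrogen.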